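Removing the ring-nitrogen substituent: a cytotoxicity outlook

The source may report more compounds than this note shows. Statements on the series, on what has been measured and on what is new or still open speak of the compounds shown alone.

Of the compounds shown here, three sharing one core have been tested in an ADME assay on HeLa cells (Homo sapiens) for cytotoxicity, read by ATP content, with a stated time of 3 days; a lower number here means that less compound is tolerated, a higher number that more compound is tolerated. Compound 1 `CS(=O)(=O)CCCn1c(Cn2c(=O)n(C3CN(S(C)(=O)=O)C3)c3ccncc32)cc2cc(Cl)ccc21` carries a 1-(methylsulfonyl)azetidin-3-yl group on an aromatic nitrogen. In this assay compound 1 reaches only the limit > 50000 nM. Compound 2 `CS(=O)(=O)CCCn1c(Cn2c(=O)n(CC#N)c3ccncc32)cc2cc(Cl)ccc21` replaces that group with cyanomethyl, and in this assay compound 2 likewise stops at the limit > 50000 nM. Compound 3 `CS(=O)(=O)CCCn1c(Cn2c(=O)n(CC3CC3)c3ccncc32)cc2cc(Cl)ccc21` instead bears cyclopropylmethyl, and in this assay compound 3 also gives only the limit > 50000 nM. Because of the limit of > 50000 nM in this assay, at which 3 of the 3 values shown sit, none of the three steps can be sized: a step that the two limits leave unreadable from compound 1 to compound 2, a step that the two limits leave unreadable from compound 1 to compound 3 and a step that the two limits leave unreadable from compound 2 to compound 3 all remain unreadable.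

Compound 4 `CS(=O)(=O)CCCn1c(Cn2c(=O)[nH]c3ccncc32)cc2cc(Cl)ccc21` takes the change (hydrogen in place of cyclopropylmethyl on an aromatic nitrogen). Going by the values given here, no measured step bears on this change directly, and the three measured steps give no readable size, so no step beyond the scatter is expected in this assay, in either direction. Compound 4 is therefore expected to give about 50000 nM, within 15000 nM to 200000 nM, which means an estimated step of a number no higher from compound 3 to compound 4 (the limit leaves the size open).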

Compound 4, half-maximal cytotoxic concentration: > 50000 nM
Compound 4 gave a limit, no number; the forecaster's own chance of this, stated with the estimate: 85%; the middle value lies on the limit itself.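

In this assay compound 4 gives > 50000 nM as a limit, not a number. Going by these compounds alone, no step between compound 4 and compound 1, compound 2 or compound 3 can be read, because of one shared ceiling: the limit of > 50000 nM in this assay, at which 4 of the 4 values shown sit.

The compounds shown leave open how much of each compound is tolerated, and whether the group on the aromatic nitrogen matters at all.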